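Fluoro in Place of Trifluoromethyl on Compound 1

The source may report more compounds than this note shows. Statements on the series, on what has been measured and on what is new or still open speak of the compounds shown alone.

Compound 1 `COc1cc(C(=O)N/N=C/c2ccc(C(F)(F)F)cc2)cc(OC)c1OC` gives 47.4% in a functional assay on BGC-823 cells (Homo sapiens) for antiproliferative activity, read by MTT assay, tested at 1 uM; on this read-out higher numbers stand for a stronger effect at the one concentration tested and lower numbers for a weaker effect.
Compound 2 `COc1cc(C2=NN(C(C)=O)C(c3c(Cl)cccc3Cl)O2)cc(OC)c1OC` gives -1.4% in this assay.
Compound 3 `COc1cc(C2=NN(C(C)=O)C(c3ccc(Cl)c(Cl)c3)O2)cc(OC)c1OC` gives -0.8% in this assay.

Compound 1 holds the highest of the three numbers in this assay; compound 3 sits nearest to it, and compound 2 furthest, both beyond the scatter. Going by the values given here, the one measured step, a number 0.6 percentage points higher from compound 2 to compound 3 (within the scatter), concerns two compounds that share a core different from that of compound 1 and lies within the scatter, so it says nothing about a change on the aryl ring of the hydrazone.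

Compound 4 `COc1cc(C(=O)N/N=C/c2ccc(F)cc2)cc(OC)c1OC` differs from compound 1 only in one place: fluoro in place of trifluoromethyl on an aromatic carbon. Among the compounds with values here, no measured pair shows what this exchange does in this assay. Lacking any step that bears on it, the expectation for compound 4 is that it stays close to compound 1, with a step of a number 5.4 percentage points lower from compound 1 to compound 4 (within the scatter) that is expected to remain within the scatter. Compound 4 is therefore estimated at 42% in this assay, with a range from 20% to 62% that reflects the lack of a directly comparable step.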

Compound 4, a percentage reported as inhibition, at one concentration (the size of the read-out at that concentration, not a potency): 50.9%
Compound 4: the middle estimate sits 8.9 percentage points below what was measured; the measured number falls inside the stated range.
By their numbers in this assay, from the lowest: compounds 2 and 3 (each within the scatter of the next); then compounds 1 and 4 (each within the scatter of the next).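

In this assay, fluoro in place of trifluoromethyl on an aromatic carbon gives a number 3.5 percentage points higher from compound 1 to compound 4 (within the scatter), the only step shown at this position. Going by these compounds alone, on the core of compound 1, the group para to a large group can thus shrink from 4 heavy atoms to 1 heavy atom with no change in the read-out beyond the scatter, which the steps among the earlier compounds could not show. No measurement shown here accounts for this outcome.

Both groups shown at this position carry fluorine, so it remains open how the read-out would respond to an amine, a carboxylic acid or a longer chain there. As far as these compounds go, it also remains open whether the same exchange would give a similar step on a different core.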